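The source may hold more compounds than are shown below. What is called first, only, known or untested is meant among the compounds shown, and "the series" means these compounds.

Measured compounds in a functional assay on SF-268 cells (Homo sapiens) for inhibition, read by sulforhodamine B assay, with a stated time of 48 h; a higher number here means that more compound is tolerated, a lower number that less compound is tolerated:
compound 1 `Nc1cc(N)c2nc(-c3ccccc3)c(Oc3ccc(Cl)c(Cl)c3)nc2c1` — compound 1 gives < 100000 nM, which is a limit of the assay and not a number.
compound 2 `Nc1cc(N)c2nc(-c3ccccc3)c(NCc3ccc(Cl)c(Cl)c3)nc2c1` — compound 2 gives < 100000 nM, again a limit of the assay.
compound 3 `COc1ccc(CNc2nc3cc(N)cc(N)c3nc2-c2ccccc2)cc1OC` — compound 3 gives < 100000 nM, also a limit of the assay.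

Compound 3 therefore stands at the same limit as the two other compounds measured in this assay; no ordering among the three can be read from these values. For the measured compounds named here, the one step between neighbours that differ in a single place, a step that the two limits leave unreadable from compound 2 to compound 3, cannot be given a size because the limit of < 100000 nM in this assay, at which 3 of the 3 values shown sit, holds both of its ends.

Compound 4 `Nc1cc(N)c2nc(-c3ccccc3)c(NCc3ccc(F)cc3)nc2c1` is the next member. Its change against compound 3 is 4-fluorophenyl in place of 3,4-dimethoxyphenyl on a saturated chain carbon bound to a nitrogen on an aromatic ring. Going by the values given here, no measured step covers this exchange, and the one step measured gives neither size nor direction. The expectation for a step that the limit leaves unreadable from compound 3 to compound 4 is therefore no step beyond the usual scatter, carried over from the limits seen so far. For compound 4 the value estimated in this assay is 40000 nM. The range expected for compound 4 runs from 8000 nM to 100000 nM, and a further limit rather than a number is the likelier outcome.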

Compound 4, concentration lethal to 50% of the cells: 40700 nM
For compound 4 the middle estimate is 1.0-fold (0.01 log units) below the measured one; measured number inside the range.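

Compound 4 gives a number in this assay, but the steps to it from compound 1, compound 2 and compound 3 cannot be read, since each of those three stands at a limit of the assay and not at a number: the limit of < 100000 nM in this assay, at which 3 of the 4 values shown sit.

The compounds shown leave open whether 4-fluorophenyl in place of 3,4-dimethoxyphenyl moves the read-out at all, and in which direction.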